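The source may hold more compounds than are shown below. What is called first, only, known or untested is meant among the compounds shown, and "the series" means these compounds.

Measured so far:
Compound 1, `CCCCNC(=S)NCc1ccccc1`: in a functional assay on RAW264.7 cells (Mus musculus) for inhibition, read by Griess assay, with a stated time of 24 h (a lower number here means a stronger inhibitor, a higher number a weaker inhibitor), compound 1 gives 143000 nM.
Compound 2, `CC(C)NC(=S)NCc1ccccc1`: in this assay compound 2 gives >= 200000 nM, which is a limit of the assay and not a number.
Compound 3, `S=C(NCc1ccccc1)Nc1ccccn1`: in this assay compound 3 gives >= 200000 nM, likewise a limit of the assay and not a number.

Compound 2 therefore stands at the top of what this assay reports, sharing that position with compound 3 (the limit of >= 200000 nM in this assay, at which 2 of the 3 values shown sit). Among the measured compounds shown here, the only measured step involving it, an at least 1.3-fold higher number from compound 1 to compound 2 (0.14 log units; that floor lies within the scatter), is a floor that lies within the scatter, so no real direction is established between butyl and isopropyl on the amide-type nitrogen.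

Compound 4, `CCN(CC)C(=S)NCc1ccccc1`, differs from compound 2 in diethylamino in place of isopropylamino on a thiocarbonyl carbon. For the measured compounds named here, no measured step bears on removing the hydrogen-bond donor from this position; the single relevant comparison is the small alkyl change above. The expectation is consequently no step beyond the scatter, with a fair chance that this assay again reports only a limit. For compound 4 the estimate is 200000 nM, within 100000 nM to 400000 nM, which is the expected step of a number no higher from compound 2 to compound 4 (the limit leaves the size open).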

Compound 4, half-maximal inhibitory concentration: 15700 nM
The estimate for compound 4 lay 13-fold (1.11 log units) above the measured number, outside the stated range (below it).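

In this assay, the thiocarbonyl carbon now shows a clear response to its amine substituent, which the butyl and isopropyl pair could not show: diethylamino in place of isopropylamino gives an at least 12-fold lower number from compound 2 to compound 4 (1.10 log units; beyond the scatter). The comparison with a measured number, free of any limit, points the same way, with diethylamino in place of butylamino giving a 9.1-fold lower number from compound 1 to compound 4 (0.96 log units; beyond the scatter). The first of these steps is only a floor, and its true size stays unknown, as compound 2 is held at a limit of the assay: the limit of >= 200000 nM in this assay, at which 2 of the 4 values shown sit.

The compounds shown do not separate the loss of the hydrogen-bond donor in diethylamino from the change in its alkyl groups. Dimethylamino or dipropylamino on the thiocarbonyl carbon would bear on that question, and how far the response depends on chain length remains open.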